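The source may hold more compounds than are shown below. What is called first, only, known or untested is meant among the compounds shown, and "the series" means these compounds.

Compound 1 `CCCC[Te]c1ccc(C(C)NCc2ccccc2)cc1` is the starting point of this account. In a functional assay, read by spectrophotometry, with a stated time of 30 min (a lower number here means a stronger inhibitor, a higher number a weaker inhibitor), compound 1 gives 11.4 ug/mL. The closest companion is compound 2 `C/C(=N\O)c1ccc([Te]CCCO)cc1`, which in this assay gives 13.1 ug/mL, a value so near that of compound 1 that the two sit within the usual scatter of repeated measurement and cannot be told apart. Among the two numbers obtained, compound 1 therefore stands at the lower one, but only by a gap within that scatter. Compound 3 `CCCC[Se]c1ccc(C(C)NCC(C)C)cc1` is reported differently: in this assay compound 3 reaches only a limit, > 100 ug/mL, which is a boundary of the assay and not a number (the limit of > 100 ug/mL in this assay, at which 1 of the 3 values shown sits).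

Compound 4 `CCCCNC(C)c1ccc([Te]CCCC)cc1` has not yet been measured. It differs from compound 1 by propyl in place of phenyl on a saturated chain carbon bound to an amine nitrogen. Going by the values given here, no measured pair shows this single change, and compound 3 differs from compound 1 in more than one place, so it offers no clean comparison. With nothing in the measured set to anchor the size of the step, a small weakening is expected, of a size that may or may not exceed the scatter. For compound 4 in this assay the expected value is 20 ug/mL, with a range from 8 ug/mL to 60 ug/mL. This estimate means an expected step of a 1.8-fold higher number from compound 1 to compound 4 (0.24 log units; within the scatter).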

Compound 4, half-maximal inhibitory concentration: 8.63 ug/mL
Compound 4: middle estimate off by 2.3-fold (0.37 log units), on the high side; the range from low to high includes it.
By their numbers in this assay, from the lowest: compounds 4, 1 and 2 (each within the scatter of the next). At a limit, above all of these: compound 3.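

In this assay, putting propyl in place of phenyl on a saturated chain carbon bound to an amine nitrogen gives a 1.3-fold lower number from compound 1 to compound 4 (0.12 log units; within the scatter), so this single change cannot be told apart from no change at all. Going by these compounds alone, this is the first clean comparison at this place, and it shows that the six-membered aromatic ring of the phenyl can leave, with the group going from 6 heavy atoms to 3, without any measurable loss in this assay; cut one bond further out, the same difference reads benzyl to butyl. Within the data shown here, nothing measured so far offers a reason for this outcome.

As far as these compounds go, whether a longer chain, a hydroxyl group or a carboxylic acid at this place would also stay within the scatter of compound 1 remains open. The part played by selenium in place of tellurium is open as well: compound 3, which stands at a limit of the assay, differs from both compound 1 and compound 4 in more than one place, and no pair shown isolates that swap.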